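A few compounds are considered here, and "the series" means these few. Any claim that something is new, unique, unknown or untested is made for them only; others in the source may bear on it.

In an assay on HL-60 cells for agonist activity at vitamin D3 receptor (Homo sapiens), read by microscopy, with a stated time of 96 h (on this read-out higher numbers stand for an effect only at larger amounts of compound and lower numbers for an effect already at smaller amounts), compound 1 `CCN(CC)CCNC(=O)c1ccc(C(CC)(CC)c2ccc(OCC(=O)C(C)(C)C)c(C)c2)n1CC` gives 91 nM, compound 2 `CCn1c(C(=O)N(CCC#N)CCC#N)ccc1C(CC)(CC)c1ccc(OCC(=O)C(C)(C)C)c(C)c1` gives 870 nM, and compound 3 `C#CC(C)OC(=O)c1ccc(C(CC)(CC)c2ccc(OCC(=O)C(C)(C)C)c(C)c2)n1CC` gives 210 nM. Compound 3 therefore stands second highest of the three numbers, nearest to compound 1 and furthest from compound 2. Compound 4 `CCOC(=O)c1ccc(OC(=O)c2ccc(C(CC)(CC)c3ccc(OCC(=O)C(C)(C)C)c(C)c3)n2CC)cc1` differs from compound 3 by 4-(ethoxycarbonyl)phenyl in place of 1-methylprop-2-yn-1-yl on an oxygen next to a carbonyl group. Every measured step likewise changes the group on a carbonyl carbon: a 2.3-fold higher number from compound 1 to compound 3 (0.36 log units; beyond the scatter), a 4.1-fold lower number from compound 2 to compound 3 (0.62 log units; beyond the scatter) and a 9.6-fold higher number from compound 1 to compound 2 (0.98 log units; beyond the scatter), each modest yet beyond the scatter. Among the compounds with values here, no measured pair exchanges one group on an oxygen next to a carbonyl for another, so only a modest shift toward a higher number is expected. Compound 4 is expected to give 350 nM, within 110 nM to 1100 nM. The step of a 1.7-fold higher number from compound 3 to compound 4 (0.22 log units; within the scatter) is thus the estimate.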

Compound 4, half-maximal effective concentration: 45600 nM
Compound 4: middle estimate off by 130-fold (2.11 log units), on the low side; the measured number lies above the stated range.
By their numbers in this assay, from the lowest: compound 1; then compound 3; then compound 2; then compound 4.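

In this assay, the group on an oxygen next to a carbonyl group proves able to shift the number far more than any earlier change: 4-(ethoxycarbonyl)phenyl in place of 1-methylprop-2-yn-1-yl gives a 220-fold higher number from compound 3 to compound 4 (2.34 log units; beyond the scatter) on that oxygen. Measured against the other two compounds, the change is also large, with a 52-fold higher number from compound 2 to compound 4 (1.72 log units; beyond the scatter) and a 500-fold higher number from compound 1 to compound 4 (2.70 log units; beyond the scatter) as the steps, while all earlier steps were modest. On these data alone, whether the ring or its ethoxycarbonyl group drives this shift stays open, as does the effect of a plain phenyl or a 4-carboxyphenyl group there. No supporting measurement accounts for the shift.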